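The source may hold more compounds than are shown below. What is called first, only, known or untested is meant among the compounds shown, and "the series" means these compounds.

The measured compounds:

compound 1, `O=C1COc2ccc(-c3cnc(Cl)c(NS(=O)(=O)c4ccc(F)cc4)c3)cc2N1`: > 40000 nM
compound 2, `O=C1COc2ccc(-c3cnc(Cl)c(NS(=O)(=O)c4ccc(F)cc4)c3)cc2N1c1ccc(Cl)cc1`: 21600 nM
compound 3, `O=C1COc2ccc(-c3cnc4ccccc4c3)cc2N1`: > 40000 nM

All three were tested in a functional assay on A549 cells (Homo sapiens) for antiproliferative activity, read by MTT assay, with a stated time of 72 h; on this read-out lower numbers stand for stronger inhibition and higher numbers for weaker inhibition. For compound 1 the result is a limit of the assay, > 40000 nM, not a number. Compound 2 gives 21600 nM in this assay. The two share a core and differ in one place: 4-chlorophenyl in place of hydrogen on an amide-type nitrogen in a ring. The step recorded is an at least 1.8-fold lower number from compound 1 to compound 2 (0.26 log units; that floor lies within the scatter); its floor lies within the usual scatter, so the size of the gain is not pinned down. Compound 3 carries a different core, and the difference between the two cores is not broken down here. For compound 3 the result in this assay is again a limit, > 40000 nM. The picture is dominated by the limit of > 40000 nM in this assay, at which 2 of the 3 values shown sit.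

Compound 4, `O=C1COc2ccc(-c3cnc4ccccc4c3)cc2N1c1ccc(Cl)cc1`, has not been measured. It stands to compound 3 as compound 2 stands to compound 1: 4-chlorophenyl in place of hydrogen on an amide-type nitrogen in a ring. The place of the change is the same in both pairs word for word, so this is the same change. Among the compounds with values here, the only guide is the step from compound 1 to compound 2, whose lower bound lies within the scatter, while compound 3 itself gives only a limit. The estimate therefore rests on a single uncertain step and one limit. The expected step is an at least 1.3-fold lower number from compound 3 to compound 4 (0.12 log units; that floor lies within the scatter), set alongside an at least 1.8-fold lower number from compound 1 to compound 2 (0.26 log units; that floor lies within the scatter). Compound 4 is estimated at 30000 nM, with a range from 8000 nM to 80000 nM, and with a real chance that this assay reports only a limit.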

Compound 4, half-maximal inhibitory concentration: > 40000 nM
Compound 4: no number, only a limit (the forecaster's own chance of this, stated with the estimate: 50%); middle value at least 1.3-fold (0.12 log units) away from the limit.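

In this assay compound 4 gives > 40000 nM, a limit of the assay and not a number. Compound 3 also gives only a limit, so no step can be read from compound 3 to compound 4. The series now sits mostly at one ceiling: the limit of > 40000 nM in this assay, at which 3 of the 4 values shown sit.

The compounds shown leave open whether 4-chlorophenyl on the amide-type nitrogen changes the antiproliferative read-out at all on the core of compound 3.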